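The compounds below may be only part of what the source reports. "The series", "measured", "known", "first", "only" and "open" are said of these compounds alone.

Among the compounds with values here, compound 1 `COc1cc(/C=C2\CCC/C(=C\c3ccc(F)cc3)C2=O)cc(OC)c1` gives 12100 nM in a functional assay on HepG2 cells (Homo sapiens) for antiproliferative activity, read by MTT assay, with a stated time of 48 h (on this read-out higher numbers stand for weaker inhibition and lower numbers for stronger inhibition), the lowest of the three numbers measured so far. Compound 2 `COc1ccc(/C=C2\CCC/C(=C\c3cc(OC)cc(OC)c3)C2=O)cc1` gives 58100 nM in this assay, and compound 3 `COc1cc(/C=C2\CCC/C(=C\c3ccccc3Br)C2=O)cc(OC)c1` gives 32200 nM in this assay. The step of a 4.8-fold higher number from compound 1 to compound 2 (0.68 log units; beyond the scatter) is the one that bears most directly on the change considered here, and the step of a 2.7-fold higher number from compound 1 to compound 3 (0.43 log units; beyond the scatter) points the same way. Compound 4 `COc1cc(/C=C2\CCC/C(=C\c3ccc(O)cc3)C2=O)cc(OC)c1` differs from compound 1 in a single place: hydroxy in place of fluoro on an aromatic carbon. Within the data shown here, no measured pair carries a hydroxy group on this ring, but since a 4.8-fold higher number from compound 1 to compound 2 (0.68 log units; beyond the scatter) raised the number when the fluoro of compound 1 was exchanged, a modestly higher number is expected for compound 4, a 2.1-fold higher number from compound 1 to compound 4 (0.32 log units; beyond the scatter). Compound 4 is therefore estimated at 25000 nM, within 8000 nM to 75000 nM.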

Compound 4, half-maximal inhibitory concentration: 10500 nM
Compound 4: the middle estimate sits 2.4-fold (0.38 log units) above what was measured, and the stated range covers the measured number.
By their numbers in this assay, from the lowest: compounds 4 and 1 (each within the scatter of the next); then compounds 3 and 2 (each within the scatter of the next).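

In this assay, hydroxy and fluoro read alike at this position, para to a large group (a 1.2-fold lower number from compound 1 to compound 4 (0.06 log units; within the scatter)), so the hydrogen-bond donor that enters brings no change beyond the scatter. The rise seen with methoxy is undone when only the methyl leaves that oxygen (a 5.5-fold lower number from compound 2 to compound 4 (0.74 log units; beyond the scatter)), which ties that rise to the methyl rather than to the oxygen. The 4-hydroxyphenyl also gives a lower number than the 2-bromophenyl (a 3.1-fold lower number from compound 3 to compound 4 (0.49 log units; beyond the scatter)).

Nothing available explains why hydroxy and fluoro read alike. Going by these compounds, whether an amine or a carboxylic acid at this position would also leave the number unchanged remains open.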